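Pyrrolidinyl to isopropylpiperidinyl on the azaindole nitrogen

A few compounds are considered here, and "the series" means these few. Any claim that something is new, unique, unknown or untested is made for them only; others in the source may bear on it.

Measured so far:
compound 1 `O=S(=O)(c1cccc(F)c1)c1cn(C2CCNC2)c2ncccc12`: 2.7 nM
compound 2 `O=S(=O)(c1cccc(Br)c1)c1cn(C2CCNC2)c2ncccc12`: 1.3 nM

In an assay on HeLa cells for displacement of a labelled ligand from 5-hydroxytryptamine receptor 6 (Homo sapiens) (a higher number here means a weaker inhibitor, a lower number a stronger inhibitor), compound 1 gives 2.7 nM, the higher of the two numbers recorded; its nearest neighbour is compound 2, with a 2.1-fold lower number from compound 1 to compound 2 (0.32 log units; beyond the scatter). Compound 3 `CC(C)N1CCCC(n2cc(S(=O)(=O)c3cccc(F)c3)c3cccnc32)C1` has not yet been measured. It differs from compound 1 in one place: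

1-isopropylpiperidin-3-yl in place of pyrrolidin-3-yl on an aromatic nitrogen

For the measured compounds named here, neither measured step bears on this change: the only step recorded, from compound 1 to compound 2, concerns bromo in place of fluoro on an aromatic carbon and leaves the group on the aromatic nitrogen untouched. No guidance on the size of the step is therefore available, and the expectation rests on the change alone. The author expects a step of a 3.0-fold higher number from compound 1 to compound 3 (0.47 log units; beyond the scatter) for compound 3, that is, a somewhat higher number. Compound 3 is estimated at 8 nM, between 1.5 nM and 50 nM.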

Compound 3, inhibition constant: 3.4 nM
Estimate against measurement, compound 3: 2.4-fold (0.37 log units) above; low and high end bracket the measured number.
By their numbers in this assay, from the lowest: compound 2; then compounds 1 and 3 (each within the scatter of the next).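

In this assay the group on the aromatic nitrogen takes a large change with little effect, as 1-isopropylpiperidin-3-yl replacing pyrrolidin-3-yl gives a 1.3-fold higher number from compound 1 to compound 3 (0.10 log units; within the scatter). The entering group has 9 heavy atoms against 5, a six-membered ring in place of a five-membered one and 0 hydrogen-bond donors against 1, so in this pair a hydrogen-bond donor on this group is not needed to keep the number within the scatter. No evidence is available to explain this result.

The ring size and the isopropyl group change together here, which leaves the separate contribution of each open, as a piperidin-3-yl without the isopropyl or a 1-isopropylpyrrolidin-3-yl would show. Also open, from the compounds shown here alone, are whether bromo in place of fluoro gives a similar step with the new group, and how a carboxylic acid on the ring nitrogen would fare.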